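A few compounds are considered here, and "the series" means these few. Any claim that something is new, unique, unknown or untested is made for them only; others in the source may bear on it.

Working notes on the series. For the measured compounds named here, in a functional assay on KBVIN cells (Homo sapiens) for antiproliferative activity, read by sulforhodamine B assay, with a stated time of 3 days (on this read-out higher numbers stand for an effect only at larger amounts of compound and lower numbers for an effect already at smaller amounts), compound 2 (`CCCC1=C(OCCC(C)C)C(CCC)(CCC)C(=O)/C(=C(O)\C=C\c2ccccc2)C1=O`) gives 19.2 uM and holds the highest number of the three measured so far. Compound 3 (`COC1=C(CC(C)C)C(=O)/C(=C(O)/C=C/c2ccccc2)C(=O)C1(CC(C)C)CC(C)C`) gives 8.2 uM and lies nearest below it, while compound 1 (`CCCC1=C(OC)C(CCC)(CCC)C(=O)/C(=C(O)\C=C\c2ccc(I)cc2)C1=O`) gives 1.4 uM and lies furthest below it. Both gaps are beyond the usual scatter.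

Compound 4 (`CCCCOC1=C(CCC)C(=O)/C(=C(O)/C=C/c2ccccc2)C(=O)C1(CCC)CCC`) departs from compound 2 by a single change (hydrogen in place of methyl on a saturated chain carbon bound to two saturated chain carbons), hydrogen in place of methyl on a saturated chain carbon bound to two saturated chain carbons, which cut one bond further out reads isopentyl to butyl. Going by the values given here, no pair of measured compounds differing in one place is available, so this change has no direct precedent.

In this assay no step beyond the scatter is expected, with a slight lean towards a lower number, since compound 2 at 19.2 uM sits at the top of the measured range. The estimated step of a 1.5-fold lower number from compound 2 to compound 4 (0.17 log units; within the scatter) is expected to stay within the scatter. Compound 4 is estimated at 13 uM with an expected range of 5 uM to 30 uM as a working figure.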

Compound 4, concentration for half-maximal effect: 8.9 uM
The estimate for compound 4 lay 1.5-fold (0.16 log units) above the measured number; the measured number falls inside the stated range.
By their numbers in this assay, from the lowest: compound 1; then compounds 3 and 4 (each within the scatter of the next); then compound 2.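

In this assay, the series now has its first pair differing in one place, and it gives a 2.2-fold lower number from compound 2 to compound 4 (0.33 log units; beyond the scatter). Hydrogen in place of methyl on a saturated chain carbon bound to two saturated chain carbons, which reads isopentyl to butyl, is therefore a modest change beyond the scatter and not a silent one, a reading the earlier compounds could not give. This holds for compound 2 as the starting point only, and nothing shown gives a reason for the step.

The compounds shown leave open whether a shorter propyl chain at this place would continue the step in the same direction. Also open, from the compounds shown here alone, is how a longer chain such as hexyl, or an amine at the end of the butyl chain, would read here.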